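This account rests on a few compounds, and the source may have more. Where it says the series, first, only, none or still open, it means among the compounds named here.

In a functional assay on P388 cells (Mus musculus) for cytotoxicity (on this read-out higher numbers stand for weaker inhibition and lower numbers for stronger inhibition), the values so far are
- compound 1 `COc1ccc(C[C@H]2C(=O)N[C@@H](C)C(=O)N(C)[C@H]3Cc4ccc(cc4)Oc4cc(ccc4OC)C[C@@H](C(=O)N[C@H](C)C(=O)N[C@@H](CC=O)C(=O)N2C)N(C)C3=O)cc1` gives 33.9 nM
- compound 2 `CCC[C@@H]1NC(=O)[C@@H](C)NC(=O)[C@@H]2Cc3ccc(OC)c(c3)Oc3ccc(cc3)C[C@@H](C(=O)N2C)N(C)C(=O)[C@H](C)NC(=O)[C@H](Cc2ccc(OC)cc2)N(C)C1=O` gives 13.8 nM

Compound 2 has the lower number of the two. Compound 3 `COc1ccc(C[C@H]2C(=O)N[C@@H](C)C(=O)N(C)[C@H]3Cc4ccc(cc4)Oc4cc(ccc4OC)C[C@@H](C(=O)N[C@H](C)C(=O)N[C@@H](CCO)C(=O)N2C)N(C)C3=O)cc1` differs from it by hydroxy in place of methyl on a saturated chain carbon, two bonds along the chain from a saturated ring carbon with hydroxy in place of methyl on a saturated chain carbon, two bonds along the chain from a saturated ring carbon. Among the measured compounds shown here, the one measured step on this chain is a 2.5-fold lower number from compound 1 to compound 2 (0.39 log units; beyond the scatter) and it is modest. Compound 3 carries oxygen on that chain as compound 1 does, so a step of similar size back toward compound 1 at 33.9 nM is expected in this assay as a rise in the number. The expected change is a 2.2-fold higher number from compound 2 to compound 3 (0.34 log units; beyond the scatter) in this estimate. For compound 3 the estimated value is 30 nM with an expected range from 12 nM to 80 nM in this read-out.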

Compound 3, half-maximal inhibitory concentration: 60.3 nM
Estimate against measurement, compound 3: 2.0-fold (0.30 log units) below; the range from low to high includes it.
By their numbers in this assay, from the lowest: compound 2; then compounds 1 and 3 (each within the scatter of the next).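

In this assay, hydroxy in place of methyl at this position on the chain gives a 4.4-fold higher number from compound 2 to compound 3 (0.64 log units; beyond the scatter) and leaves compound 2 with the lowest number of the three. Hydroxymethyl in place of formyl gives a 1.8-fold higher number from compound 1 to compound 3 (0.25 log units; within the scatter), so these two oxygen-bearing chains are not separated in this assay. No evidence on hand bears on the origin of these differences.

Only propyl and the two oxygen-bearing chains are shown here. From the compounds shown here alone, how an amine, a carboxylic acid or a chain longer than propyl would compare at this position remains open.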